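Pyrazolyl for Oxanyl: A Paired Change in Microsomal Clearance

The compounds below may be only part of what the source reports. "The series", "measured", "known", "first", "only" and "open" are said of these compounds alone.

Compound 1 `C[C@H](Nc1c(C(N)=O)nnc2ccc(-c3ccc(OCCCN4CCCC4)nc3)cc12)C1CCOCC1` and compound 2 `Cc1cn(C)nc1[C@H](C)Nc1c(C(N)=O)nnc2ccc(-c3ccc(OCCCN4CCCC4)nc3)cc12` differ in one place: 1,4-dimethyl-1H-pyrazol-3-yl in place of oxan-4-yl on a saturated chain carbon bound to a nitrogen on an aromatic ring and a saturated chain carbon. In an ADME assay on microsomes from liver (Homo sapiens) for metabolic stability, read by LC-MS, using NADPH, with a stated time of 30 min, tested at 1 uM (on this read-out lower numbers stand for slow clearance and higher numbers for fast clearance), compound 1 gives 23 mL.min-1.g-1 and compound 2 gives 40 mL.min-1.g-1, so this change produced a 1.7-fold higher number from compound 1 to compound 2 (0.24 log units; within the scatter). Compound 3 `CNC(=O)c1nnc2ccc(-c3ccc(OCCCN(C)C)nc3)cc2c1N[C@@H](C)C1CCOCC1` carries a different core; the difference between the two cores is not broken down here. In this assay compound 3 gives 22 mL.min-1.g-1, a number close to that of compound 1. Compound 4 `CNC(=O)c1nnc2ccc(-c3ccc(OCCCN(C)C)nc3)cc2c1N[C@@H](C)c1nn(C)cc1C` arises from compound 3 through the same change, (1,4-dimethyl-1H-pyrazol-3-yl in place of oxan-4-yl on a saturated chain carbon bound to a nitrogen on an aromatic ring and a saturated chain carbon), at the same place. Among the measured compounds shown here, the expected step is a 1.7-fold higher number from compound 3 to compound 4 (0.23 log units; within the scatter), about the size of the measured one, because a 1.7-fold higher number from compound 1 to compound 2 (0.24 log units; within the scatter) is the only measurement of this change available. On that basis compound 4 is estimated at 37 mL.min-1.g-1, with a likely range from 20 mL.min-1.g-1 to 70 mL.min-1.g-1.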

Compound 4, intrinsic clearance in microsomes: 33 mL.min-1.g-1
Compound 4: middle estimate off by 1.1-fold (0.05 log units), on the high side; the measured number falls inside the stated range.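

Carried to the core of compound 3, 1,4-dimethyl-1H-pyrazol-3-yl in place of oxan-4-yl gives, in this assay, a 1.5-fold higher number from compound 3 to compound 4 (0.18 log units; within the scatter). The step on this core agrees with the step on the core of compound 1: the same change on two cores in this assay, a 1.7-fold higher number (0.24 log units; within the scatter) from compound 1 to compound 2 and a 1.5-fold higher number (0.18 log units; within the scatter) from compound 3 to compound 4, 1.2-fold (0.06 log units) apart, within the scatter of two such steps Since each step lies within the scatter, the two pairs show that the change reads alike on these two cores, but they do not establish that the change itself moves intrinsic clearance, and they say nothing about any other core.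

The compounds shown leave open how a phenyl or a cyclohexyl group would read in this assay at the same place, on a saturated chain carbon bound to a nitrogen on an aromatic ring and a saturated chain carbon.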